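Pendant ring swap: from a chloro to two fluorines

The source may report more compounds than this note shows. Statements on the series, on what has been measured and on what is new or still open speak of the compounds shown alone.

Compound 1, `Cc1ccc(-c2nnc(COc3cnn(C(C)(C)C)c(=O)c3Cl)o2)cc1`, gives 19900 nM in a functional assay on the whole organism for inhibition, with Mythimna separata as the target, with a stated time of 5 days; a lower number here means that less compound is needed, a higher number that more compound is needed for the effect. Compound 2, `Cc1cc(C)cc(-c2nnc(COc3cnn(C(C)(C)C)c(=O)c3Cl)o2)c1`, reaches only a limit of this assay at > 299000 nM. Compound 3, `CC(C)(C)n1ncc(OCc2nnc(-c3ccc(Cl)cc3)o2)c(Cl)c1=O`, gives 1900 nM.

All three share one core and differ only in the aryl group on the five-membered ring. Going by these compounds, compound 3 holds the lowest of the two numbers: the step of a 10-fold lower number from compound 1 to compound 3 (1.02 log units; beyond the scatter) shows that a chloro where a methyl stood lowers the number substantially, and the step of an at least 150-fold lower number from compound 2 to compound 3 (2.19 log units; beyond the scatter) shows a far larger gap, though compound 2 sits at a limit (the limit of > 299000 nM in this assay, at which 1 of the 3 values shown sits) so its true distance is unknown. The step of an at least 15-fold higher number from compound 1 to compound 2 (1.17 log units; beyond the scatter) shows that moving from one methyl to two methyls at other positions raised the number markedly.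

Compound 4, `CC(C)(C)n1ncc(OCc2nnc(-c3c(F)cccc3F)o2)c(Cl)c1=O`, introduces the change (2,6-difluorophenyl in place of 4-chlorophenyl on an aromatic carbon). Going by the values given here, no measured step covers a 2,6-difluorophenyl, but both the nature of the substituent and its pattern shifted numbers by large amounts in the steps above, and the two-substituent pattern of compound 2 was the worst case seen. A higher number than compound 3 is therefore expected for compound 4, estimated as a 6.3-fold higher number from compound 3 to compound 4 (0.80 log units; beyond the scatter), giving 12000 nM with a range from 2000 nM to 100000 nM.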

Compound 4, half-maximal effective concentration: 45400 nM
Compound 4: the middle estimate sits 3.8-fold (0.58 log units) below what was measured; the measured number falls inside the stated range.
By their numbers in this assay, from the lowest: compound 3; then compound 1; then compound 4. At a limit, above all of these: compound 2.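

In this assay, a halogen on the pendant ring is not enough on its own to give a low number: the earlier chloro-for-methyl step might have suggested that it was, yet 2,6-difluorophenyl in place of 4-chlorophenyl gives a 24-fold higher number from compound 3 to compound 4 (1.38 log units; beyond the scatter). The two fluorines do not even match the single methyl, since the comparison with the 4-methylphenyl group gives a 2.3-fold higher number from compound 1 to compound 4 (0.36 log units; beyond the scatter), so among these four compounds, halogen-bearing rings fall on both sides of compound 1. A ring with two substituents also need not be as poor as the 3,5-dimethylphenyl ring of compound 2, as an at least 6.5-fold lower number from compound 2 to compound 4 (0.81 log units; beyond the scatter) shows, although compound 2 sits at a limit and this gap is only a minimum: the limit of > 299000 nM in this assay, at which 1 of the 4 values shown sits.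

The compounds shown do not separate the kind of halogen from its pattern on the ring, and a 4-fluorophenyl or a 2,6-dichlorophenyl group would be needed to pull those two apart. They also leave open how this position would respond to a group carrying oxygen or nitrogen, such as a 4-methoxyphenyl or a 4-aminophenyl.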